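This account rests on a few compounds, and the source may have more. Where it says the series, first, only, none or still open, it means among the compounds named here.

Measured so far:
- compound 1 `C=C(Br)C(=O)Nc1ccc(/C=C2\SC(=O)N(Cc3cccc(F)c3)C2=O)cc1` — 5900 nM
- compound 2 `Nc1ccc(/C=C2\SC(=O)N(Cc3cccc(F)c3)C2=O)cc1` — 250000 nM

In a functional assay on HeLa cells (Homo sapiens) for cytotoxicity, read by cell counting, with a stated time of 4 days (a higher number here means a weaker inhibitor, a lower number a stronger inhibitor), compound 1 gives 5900 nM, the lowest of the two numbers; compound 2 gives 250000 nM. Going by the values given here, the one measured step, a 42-fold higher number from compound 1 to compound 2 (1.63 log units; beyond the scatter), concerns hydrogen in place of (1-bromoethenyl)carbonyl on a nitrogen on an aromatic ring, a large change.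

Compound 3 `C=C(Br)C(=O)Nc1ccc(/C=C2\SC(=O)N(CC)C2=O)cc1` differs from compound 1 elsewhere: methyl in place of 3-fluorophenyl on a saturated chain carbon bound to an amide-type nitrogen in a ring. The (1-bromoethenyl)carbonyl group of compound 1 is kept. Among the compounds with values here, no measured step touches the group on the saturated chain carbon bound to the amide-type nitrogen in the ring, so there is nothing to read the size of this change from; the step from compound 1 to compound 2 does not bear on it. The expectation for compound 3 is therefore a moderate loss, a 2.0-fold higher number from compound 1 to compound 3 (0.31 log units; beyond the scatter), with wide uncertainty. Compound 3 is estimated at 12000 nM, in the range 3000 nM to 50000 nM.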

Compound 3, half-maximal inhibitory concentration: 1400 nM
Estimate against measurement, compound 3: 8.6-fold (0.93 log units) above; measured number outside the range, below it.
By their numbers in this assay, from the lowest: compound 3; then compound 1; then compound 2.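

In this assay, methyl in place of 3-fluorophenyl on a saturated chain carbon bound to an amide-type nitrogen in a ring gives a 4.2-fold lower number from compound 1 to compound 3 (0.62 log units; beyond the scatter) as a modest step, so the 3-fluorobenzyl group is not required for a number in this range. The number therefore responds to this position as well as to the (1-bromoethenyl)carbonyl group, which is kept in both compounds of this step. No supporting data bear on the reason for this shift.

A longer chain, a carboxylic acid or an amine at this position could show whether the number keeps falling or turns back. On these data alone, it also remains open whether the ethyl group would have a comparable effect in a compound carrying a free aromatic amine instead of the (1-bromoethenyl)carbonyl group.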